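Swapping the imidazole for an isopropyl-thiadiazole

A few compounds are considered here, and "the series" means these few. Any claim that something is new, unique, unknown or untested is made for them only; others in the source may bear on it.

Measured so far:
- compound 1, `Cc1ccccc1OC1CCN(c2ccc(-n3ccnc3)nn2)CC1`: 39 nM
- compound 2, `Brc1ccccc1OC1CCN(c2ccc(-n3ccnc3)nn2)CC1`: 5 nM
- compound 3, `FC(F)(F)c1ccccc1OC1CCN(c2ccc(-n3ccnc3)nn2)CC1`: 4 nM

All three share one core and differ only in the group on the outer benzene ring. In an assay on microsomes from liver for inhibition of acyl-CoA desaturase 1 (Rattus norvegicus) (on this read-out lower numbers stand for stronger inhibition and higher numbers for weaker inhibition), compound 3 gives the lowest number of the three. Its nearest neighbour is compound 2, and the gap between them, a 1.3-fold lower number from compound 2 to compound 3 (0.10 log units; within the scatter), is too small to separate them. The step of a 9.8-fold lower number from compound 1 to compound 3 (0.99 log units; beyond the scatter), like a 7.8-fold lower number from compound 1 to compound 2 (0.89 log units; beyond the scatter), is clearly larger.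

Compound 4, `CC(C)c1nnc(-c2ccc(N3CCC(Oc4ccccc4C(F)(F)F)CC3)nn2)s1`, keeps the trifluoromethyl of compound 3 and changes the other end of the molecule: 5-isopropyl-1,3,4-thiadiazol-2-yl in place of 1H-imidazol-1-yl on an aromatic carbon. Among the compounds with values here, none of the measured steps touches this position; all of them concern the benzene ring. So no measured step bears on this change, and the only anchor is the value of compound 3.

With that anchor alone, compound 4 is expected to land near compound 3 in this assay, at about 5 nM, with a wide range from 1 nM to 30 nM, which is expected to correspond to the step of a 1.3-fold higher number from compound 3 to compound 4 (0.10 log units; within the scatter).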

Compound 4, half-maximal inhibitory concentration: 8.8 nM
Beside the measured number, compound 4's estimate is 1.8-fold (0.25 log units) below it, and the stated range covers the measured number.
By their numbers in this assay, from the lowest: compounds 3, 2 and 4 (each within the scatter of the next, the first and the last beyond it); then compound 1.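

Within the data shown here, this is the first measured change away from the benzene ring, and in this assay the exchange of 1H-imidazol-1-yl for 5-isopropyl-1,3,4-thiadiazol-2-yl gives a 2.2-fold higher number from compound 3 to compound 4 (0.34 log units; beyond the scatter) in a modest step. It shows that the position tolerates a different five-membered aromatic ring carrying a branched group, and that 1H-imidazol-1-yl is not required for a low number, with compound 4 still at 8.8 nM in this assay. Nothing measured here explains the size or direction of this step.

The compounds shown leave open how much of the step belongs to the thiadiazole ring and how much to its isopropyl group, which a methyl or a cyclopropyl in that place would help to separate. On these data alone, it also remains open how an amine or a carboxylic acid on this ring would fare at this position.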